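The source may hold more compounds than are shown below. What is called first, only, known or untested is meant among the compounds shown, and "the series" means these compounds.

Measured so far:
compound 1 `COc1ncnc2c1c(-c1ccoc1)cn2[C@@H]1O[C@H](CO)[C@@H](O)[C@H]1O` — 1790 nM
compound 3 `COc1ncnc2c1c(-c1cc3ccccc3o1)cn2[C@@H]1O[C@H](CO)[C@@H](O)[C@H]1O` — 9240 nM
compound 2 `CNc1ncnc2c1c(-c1ccoc1)cn2[C@@H]1O[C@H](CO)[C@@H](O)[C@H]1O` — a limit only, see below

In a functional assay on HeLa S3 cells (Homo sapiens) for antiproliferative activity, read by XTT assay, with a stated time of 72 h (on this read-out lower numbers stand for stronger inhibition and higher numbers for weaker inhibition), compound 1 gives 1790 nM and compound 3 gives 9240 nM. For compound 2 the assay reports only a limit, > 20000 nM, as recorded in the limit of > 20000 nM in this assay, at which 1 of the 3 values shown sits. The change from compound 1 to compound 2 is methylamino in place of methoxy on an aromatic carbon and it made an at least 11-fold higher number from compound 1 to compound 2 (1.04 log units; beyond the scatter). The two cores differ by 1-benzofuran-2-yl in place of furan-3-yl on an aromatic carbon, which made a 5.2-fold higher number from compound 1 to compound 3 (0.71 log units; beyond the scatter).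

Compound 4 `CNc1ncnc2c1c(-c1cc3ccccc3o1)cn2[C@@H]1O[C@H](CO)[C@@H](O)[C@H]1O` is not yet measured. It differs from compound 3 by methylamino in place of methoxy on an aromatic carbon; the place lines of the two changes agree word for word, so this is the same change as from compound 1 to compound 2. With compound 3 already at 9240 nM and the earlier change having given an at least 11-fold higher number from compound 1 to compound 2 (1.04 log units; beyond the scatter), the step from compound 3 to compound 4 in this assay is expected to be a 6.5-fold higher number from compound 3 to compound 4 (0.81 log units; beyond the scatter) or larger. Compound 4 is accordingly estimated at 60000 nM, within 15000 nM to 300000 nM.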

Compound 4, half-maximal inhibitory concentration: > 20000 nM
Compound 4: a limit, no number (the forecaster's own chance of this, stated with the estimate: 75%); the middle value is on the limit's open side.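

Compound 4 is reported in this assay only as a limit, > 20000 nM, and the step that links it to compound 2 cannot be read. Methylamino in place of methoxy gives a higher number on both cores, here with an at least 2.1-fold higher number from compound 3 to compound 4 (0.33 log units; beyond the scatter), so among the compounds shown the direction of the change carries from the core of compound 1 to the core of compound 3, and no compound goes against it. The size of the change does not carry over as a figure, and the two steps cannot be set against each other: the same change on two cores in this assay, an at least 11-fold higher number (1.04 log units; beyond the scatter) from compound 1 to compound 2 and an at least 2.1-fold higher number (0.33 log units; beyond the scatter) from compound 3 to compound 4; the limit leaves it open whether they differ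

Still open, going by these compounds, is how far compound 2 and compound 4 each lie past the limit, and so whether the change has the same size on both cores. Also open, on these data alone, is how other groups in place of methoxy, such as ethoxy, a primary amine or dimethylamino, behave on either core.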